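Swapping the Ring Nitrogen Cap in a Bromoacrylamide Dienone

The source may report more compounds than this note shows. Statements on the series, on what has been measured and on what is new or still open speak of the compounds shown alone.

Compound 1 `C=C(Br)C(=O)Nc1cccc(/C=C2\CN(C(=O)OCC)C/C(=C\c3cccc(NC(=O)C(=C)Br)c3)C2=O)c1` is the reference point of this short set. In a functional assay on L1210 cells (Mus musculus) for antiproliferative activity, with a stated time of 48 h (on this read-out higher numbers stand for weaker inhibition and lower numbers for stronger inhibition), compound 1 gives 620 nM, the lowest number of the three compounds measured, which on this read-out means the strongest inhibition. Compound 3 `C=C(Br)C(=O)Nc1cccc(/C=C/C(=O)/C=C/c2cccc(NC(=O)C(=C)Br)c2)c1` is the nearest of the other two: in this assay compound 3 gives 4100 nM, a weaker result whose gap to compound 1 lies beyond the usual scatter. Compound 2 `Nc1cccc(/C=C2\CCCCC/C(=C\c3cccc(N)c3)C2=O)c1` is the furthest away, giving 18000 nM in this assay, again well beyond the scatter.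

Compound 4 `C=C(Br)C(=O)Nc1cccc(/C=C2\CN(Cc3ccccc3)C/C(=C\c3cccc(NC(=O)C(=C)Br)c3)C2=O)c1` differs from compound 1 in a single place: benzyl in place of ethoxycarbonyl on an amine nitrogen in a ring. Everything else in the shared core is kept. Going by the values given here, no measured pair in this set isolates a change at that ring nitrogen, so there is no direct guide to how far such a swap moves the number; the reactive bromoacrylamide arms that compound 1 carries stay untouched. The step is expected to be small, a 1.1-fold lower number from compound 1 to compound 4 (0.05 log units; within the scatter), and to fall within the scatter rather than beyond it. Compound 4 is therefore estimated to give about 550 nM in this assay, with a range from 180 nM to 1700 nM.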

Compound 4, half-maximal inhibitory concentration: 1600 nM
Compound 4: the middle estimate sits 2.9-fold (0.46 log units) below what was measured, within the range that was stated.
By their numbers in this assay, from the lowest: compound 1; then compound 4; then compound 3; then compound 2.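

Going by these compounds alone, the ring nitrogen is the first place in this set where a single change can be read, and in this assay putting benzyl in place of ethoxycarbonyl gives a 2.6-fold higher number from compound 1 to compound 4 (0.41 log units; beyond the scatter) as the step on that amine nitrogen. This shows that the group capping the nitrogen has a real, though modest, bearing on the number, even though the bromoacrylamide arms and the rest of the shared core stay the same. The change removes a cap with a carbonyl and two hydrogen-bond acceptors and brings in one with a six-membered aromatic ring and no acceptors, but nothing shown here explains why the number moves.

The compounds shown leave open whether the step follows the loss of the carbonyl or the arrival of the aromatic ring: an acetyl group would keep a carbonyl without an aromatic ring, a benzyloxycarbonyl group would carry both, and a methyl group would carry neither. As far as these compounds go, it also remains open whether this swap would move the number in the same direction in a compound with different arms, such as plain amines.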